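Ethyl for methyl on the core: cytotoxicity notes

The source may hold more compounds than are shown below. What is called first, only, known or untested is meant among the compounds shown, and "the series" means these compounds.

Compound 2 `CCCNc1nc(C)nc2c1cnn2-c1ccccc1` carries the shared core with a propyl on a nitrogen on an aromatic ring and a methyl on an aromatic carbon. In a functional assay on G-361 cells (Homo sapiens) for cytotoxicity, read by sulforhodamine B assay (a higher number here means that more compound is tolerated, a lower number that less compound is tolerated), compound 2 gives > 100000 nM, a limit of the assay rather than a number. Compound 1 `CCCNc1ncnc2c1cnn2-c1ccccc1` lacks that methyl. In this assay compound 1 gives > 100000 nM, also a limit. Compound 3 `Cc1nc(Nc2ccccc2)c2cnn(-c3ccccc3)c2n1` has phenyl in place of propyl on that nitrogen. In this assay compound 3 gives > 100000 nM, again a limit. The steps a step that the two limits leave unreadable from compound 1 to compound 2 and a step that the two limits leave unreadable from compound 2 to compound 3 stay unreadable because of the limit of > 100000 nM in this assay, at which 3 of the 3 values shown sit. Compound 4 `CCCNc1nc(CC)nc2c1cnn2-c1ccccc1` differs from compound 2 by methyl in place of hydrogen on a saturated chain carbon bound to an aromatic carbon. Neither measured step bears on this change. Compound 4 is expected to remain at the limit, the step that the limit leaves unreadable from compound 2 to compound 4 being estimated as none beyond the scatter. Compound 4 is estimated at 150000 nM, range 60000 nM to 400000 nM.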

Compound 4, concentration lethal to 50% of the cells: > 100000 nM
Compound 4 gave a limit, no number; the forecaster's own chance of this, stated with the estimate: 85%; the middle value lies beyond the limit too.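

Compound 4 yields no new readable step against compound 1 or compound 2 in this assay because all these values are limits, not numbers: the limit of > 100000 nM in this assay, at which 4 of the 4 values shown sit.

The compounds shown leave open whether any change on the shared core brings cytotoxicity into the measurable range.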